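The source may report more compounds than this note shows. Statements on the series, on what has been measured and on what is new or still open speak of the compounds shown alone.

compound 1 `COc1ccc(OC)c(NC(=O)CCCCCCNC(=O)C(O)(O)C(F)(F)F)c1`: 3870 nM
compound 2 `O=C(CCCCCCNC(=O)C(O)(O)C(F)(F)F)Nc1ccncc1`: 6670 nM
compound 3 `O=C(CCCCCCNC(=O)C(O)(O)C(F)(F)F)Nc1ccc(Br)cc1`: 3130 nM

These three values come from a functional assay on HCT-116 cells (Homo sapiens) for inhibition, read by colorimetric assay, with a stated time of 3 days; a lower number here means a stronger inhibitor, a higher number a weaker inhibitor. There, compound 3 gives 3130 nM, which lies within the scatter of compound 1, its nearest neighbour. Its furthest neighbour is compound 2, with a 2.1-fold lower number from compound 2 to compound 3 (0.33 log units; beyond the scatter), a modest step beyond the scatter.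

The next compound, compound 4 `COc1ccccc1NC(=O)CCCCCCNC(=O)C(O)(O)C(F)(F)F`, has 2-methoxyphenyl in place of 4-bromophenyl on an amide-type nitrogen. Among the measured compounds shown here, the only measured step at this place is the one from pyridin-4-yl to 4-bromophenyl, a 2.1-fold lower number from compound 2 to compound 3 (0.33 log units; beyond the scatter), and it only just clears the scatter. Compound 1, whose ring also bears methoxy groups, gives 3870 nM, close to compound 3. For the measured compounds named here, no measured compound isolates the 2-methoxyphenyl group itself, so the expectation stays loose: no step beyond the scatter in this assay, with a slight drift upward at most. The estimated change is a 1.2-fold higher number from compound 3 to compound 4 (0.08 log units; within the scatter). For compound 4 the expected value is 3800 nM, with an estimated range of 2000 nM to 7000 nM.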

Compound 4, half-maximal inhibitory concentration: 10100 nM
For compound 4 the middle estimate is 2.7-fold (0.42 log units) below the measured one, and the stated range ends below it.
By their numbers in this assay, from the lowest: compounds 3, 1, 2 and 4 (each within the scatter of the next, the first and the last beyond it).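

In this assay, among the compounds shown here, the ring on the amide-type nitrogen proves to matter more than the single earlier step suggested: 2-methoxyphenyl in place of 4-bromophenyl gives a 3.2-fold higher number from compound 3 to compound 4 (0.51 log units; beyond the scatter) and thus a larger step than any seen before at this place, whereas the change from pyridin-4-yl shows a 1.5-fold higher number from compound 2 to compound 4 (0.18 log units; within the scatter) and so no separation from that group. A methoxy-bearing ring does not in itself match compound 1, since hydrogen in place of methoxy on an aromatic carbon gives a 2.6-fold higher number from compound 1 to compound 4 (0.42 log units; beyond the scatter) and shows that the extra methoxy group counts here. Nothing available explains why these rings differ. From the compounds shown here alone, how 4-methoxyphenyl or 2-bromophenyl would read on the same nitrogen stays open, so the effects of the substituent and of its place on the ring cannot yet be separated. Going by these compounds, whether these differences hold with a longer chain is also open.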